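Dropping One Hydroxyethoxy Group from Compound 3

A few compounds are considered here, and "the series" means these few. Any claim that something is new, unique, unknown or untested is made for them only; others in the source may bear on it.

compound 1 `COc1cc(/C=C/C(=O)NCCn2c(C)cc3ccccc32)cc(OC)c1OCCO`: 85000 nM
compound 2 `Cc1cc2ccccc2n1CCNC(=O)/C=C/c1ccc(OCCCO)cc1`: 210000 nM
compound 3 `Cc1cc2ccccc2n1CCNC(=O)/C=C/c1ccc(OCCO)c(OCCO)c1`: 1570 nM

In a functional assay on C6 cells for antagonist activity at prostacyclin receptor (Homo sapiens), read by TR-FRET and cAMP accumulation, with stated times of 10 min and 40 min (a higher number here means a weaker inhibitor, a lower number a stronger inhibitor), compound 3 shows the lowest number of the three, and its gaps to compound 1 and compound 2 both lie beyond the usual scatter. Compound 4 `Cc1cc2ccccc2n1CCNC(=O)/C=C/c1ccc(OCCO)cc1` is its nearest relative: the change is hydrogen in place of 2-hydroxyethoxy on an aromatic carbon. Within the data shown here, no measured pair differs by exactly this step, so its size cannot be read off directly. Compound 2 carries only a single chain on the aromatic ring and in this assay compound 2 gives 210000 nM, far above compound 3. Compound 4 is therefore expected to be considerably weaker, with a step of a 64-fold higher number from compound 3 to compound 4 (1.80 log units; beyond the scatter) beyond the scatter. Compound 4 is estimated at 100000 nM, within 15000 nM to 500000 nM.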

Compound 4, antagonist equilibrium constant: 30000 nM
Estimate against measurement, compound 4: 3.3-fold (0.52 log units) above; low and high end bracket the measured number.
By their numbers in this assay, from the lowest: compound 3; then compound 4; then compound 1; then compound 2.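

In this assay, replacing the 2-hydroxyethoxy group with hydrogen gives a 19-fold higher number from compound 3 to compound 4 (1.28 log units; beyond the scatter), so a substituent at this aromatic carbon, ortho to a 2-hydroxyethoxy group, matters greatly for compound 3. Chain length also counts when the ring carries one chain: hydroxy in place of hydroxymethyl gives a 7.0-fold lower number from compound 2 to compound 4 (0.85 log units; beyond the scatter). Nothing available explains either step. The compounds shown leave open whether a smaller group such as methoxy could replace the 2-hydroxyethoxy group at this position. They also leave open how an amine, a carboxylic acid or a longer chain there would compare.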